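Mirror image of compound 3: the phosphate series on FL5.12 cells

The compounds below may be only part of what the source reports. "The series", "measured", "known", "first", "only" and "open" are said of these compounds alone.

Of the compounds shown here, three have a number so far. In a functional assay on FL5.12 cells (Mus musculus), read by flow cytometry, with a stated time of 3 h, tested at 10 uM (a lower number here means a weaker effect, a higher number a stronger effect of the compound at the concentration tested), compound 1 `CCCCCCCCc1ccc(C(=O)CC[C@H]2C[C@H](CO)CN2)cc1` gives 46%, and compound 2 `CCCCCCCCc1ccc(CC(O)[C@@H]2C[C@@H](O)CN2)cc1` gives 62%. Compound 3 `CCCCCCCCc1ccc(CC(=O)[C@@H]2C[C@@H](OP(=O)(O)O)CN2)cc1` gives 3% in this assay, the lowest of the three numbers; its nearest neighbour is compound 1, which stands higher by a difference beyond the scatter, and compound 2 stands further away still, also beyond the scatter.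

The step under consideration leads from compound 3 to compound 4 `CCCCCCCCc1ccc(CC(=O)[C@H]2C[C@H](OP(=O)(O)O)CN2)cc1`. The two compounds share every atom and bond: the two compounds have the same atoms and bonds and differ only in configuration as drawn: 2 of 2 stereo elements differ (all stereocentres are inverted: mirror images); a stereocentre at a saturated ring carbon is drawn S in compound 3 and R in compound 4; a stereocentre at a saturated ring carbon is drawn R in compound 3 and S in compound 4. Within the data shown here, no measured pair of the series shows this kind of change, so the size of the step cannot be read from other data; all that is known is that compound 3 sits at the bottom of the series.

An inversion of both stereocentres can leave the number where it is or move it a long way in either direction. Since compound 3 already sits close to zero, the step can hardly go lower, and an upward movement is the only one that can be large. The expected step from compound 3 to compound 4 in this assay is therefore a number 27 percentage points higher from compound 3 to compound 4 (beyond the scatter), a rise beyond the scatter, with wide uncertainty. For compound 4 the estimate in this assay is 30%, within a range from 3% to 65%.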

Compound 4, a percentage reported as activity, at one concentration (the size of the read-out at that concentration, not a potency): 5%
The estimate for compound 4 lay 25 percentage points above the measured number; the measured number falls inside the stated range.
By their numbers in this assay, from the lowest: compounds 3 and 4 (each within the scatter of the next); then compound 1; then compound 2.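

In this assay, inverting both stereocentres gives a number 2 percentage points higher from compound 3 to compound 4 (within the scatter), so this read-out does not separate the two mirror images. Among these compounds, this is the first pair to isolate configuration, and for this phosphate the drawn configuration at the two saturated ring carbons leaves no difference beyond the scatter at the concentration tested. In this assay compound 3 gives 3% and compound 4 gives 5%, so the low number holds for both mirror images, and the comparison is a clean one for a single reason: the fact that compounds 3 and 4 differ only in the configuration as drawn

From the compounds shown here alone, it remains open whether the low numbers follow from the phosphate itself, since the pair holds that group constant and says nothing about a free hydroxyl, a phosphonate or a carboxylic acid at that place on either mirror image. Also open, going by these compounds, is how the two forms with only one stereocentre inverted would read, and whether the two mirror images would stay together at another concentration, since a single-concentration percentage is not a potency.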